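Ethoxycarbonyl for Phenyl on a Longer Linker

The source may report more compounds than this note shows. Statements on the series, on what has been measured and on what is new or still open speak of the compounds shown alone.

Measured compounds in a functional assay on thoracic aorta (Rattus norvegicus, strain Wister); a lower number here means a stronger inhibitor, a higher number a weaker inhibitor:
compound 1, `O=C(CN1CCN(c2ccccc2)CC1)NNc1nncc2ccccc12`, gives 560000 nM
compound 2, `CCOC(=O)N1CCN(CC(=O)NNc2nncc3ccccc23)CC1`, gives > 1000000 nM
compound 3, `O=C(CCN1CCN(c2ccccc2)CC1)NNc1nncc2ccccc12`, gives 270000 nM
compound 4, `CCOC(=O)N1CCN(CCC(=O)NNc2nncc3ccccc23)CC1`, not yet measured

All four share one core, and the three measured ones have been tested in this assay. Compound 3 stands at the lowest of the two numbers shown; its nearest neighbour is compound 1, which gives 560000 nM, a step of an at least 1.7-fold higher number from compound 1 to compound 2 (0.25 log units; that floor lies within the scatter) separating compound 1 from compound 2. The value of compound 2 is a limit of the assay and not a number, so the step from compound 1 to compound 2 can only be given as a floor, and that floor lies within the scatter; still, the direction points toward a weaker inhibitor, as far as the limit of > 1000000 nM in this assay, at which 1 of the 3 values shown sits, tells.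

Compound 4 differs from compound 3 by ethoxycarbonyl in place of phenyl on an amine nitrogen in a ring, the same exchange that separates compound 2 from compound 1, here carried on the longer linker of compound 3. Within the data shown here, because the only precedent is an at least 1.7-fold higher number from compound 1 to compound 2 (0.25 log units; that floor lies within the scatter), a move toward a higher number is expected for compound 4, of a size estimated as a 2.6-fold higher number from compound 3 to compound 4 (0.41 log units; beyond the scatter), with a fair chance that only a limit is returned. Compound 4 is therefore expected to give about 700000 nM, within a range from 300000 nM to 2000000 nM.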

Compound 4, half-maximal inhibitory concentration: > 1000000 nM
Compound 4 gave a limit, no number (the forecaster's own chance of this, stated with the estimate: 35%); at least 1.4-fold (0.15 log units) between middle value and limit.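

On the longer linker, ethoxycarbonyl in place of phenyl on an amine nitrogen in a ring gives, in this assay, an at least 3.7-fold higher number from compound 3 to compound 4 (0.56 log units; beyond the scatter), so the direction that the shorter pair could only suggest, with a floor inside the scatter, can now be read beyond the scatter. Compound 4 gives > 1000000 nM, which is a limit of the assay and not a number. The change therefore points toward a weaker inhibitor on both linkers, and neither pair shown goes against this, although the size of the change on each cannot be compared: the same change on two cores in this assay, an at least 1.7-fold higher number (0.25 log units; that floor lies within the scatter) from compound 1 to compound 2 and an at least 3.7-fold higher number (0.56 log units; beyond the scatter) from compound 3 to compound 4; the limit leaves it open whether they differ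

From the compounds shown here alone, the true numbers of the two ethoxycarbonyl compounds stay unknown, so it remains open how much weaker they are than their phenyl partners and whether the linker makes any difference among them: the limit of > 1000000 nM in this assay, at which 2 of the 4 values shown sit. It is also open whether phenyl itself matters on this nitrogen or whether another group, such as benzyl or a plain methyl, would keep the numbers of the phenyl compounds.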